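A few compounds are considered here, and "the series" means these few. Any claim that something is new, unique, unknown or untested is made for them only; others in the source may bear on it.

For the measured compounds named here, in a functional assay on B16-F0 cells (Mus musculus) for inhibition, read by CCK-8 assay, with a stated time of 48 h (on this read-out lower numbers stand for stronger inhibition and higher numbers for weaker inhibition), compound 1 `COc1cc(-c2ccnc3cc(-c4ccccc4)nn23)cc(OC)c1OC` gives 4730 nM and compound 2 `COc1cc(-c2ccnc3cc(-c4ccc(C(F)(F)F)cc4)nn23)cc(OC)c1OC` gives 1770 nM, the lower of the two numbers so far. The unmeasured compound 3 `COc1cc(-c2ccnc3cc(-c4ccc5cnn(C)c5c4)nn23)cc(OC)c1OC` differs from compound 2 as follows: 1-methyl-1H-indazol-6-yl in place of 4-(trifluoromethyl)phenyl on an aromatic carbon. Going by the values given here, the only measured step bearing on this is a 2.7-fold lower number from compound 1 to compound 2 (0.43 log units; beyond the scatter), a change within the group now replaced. Among the compounds with values here, no measured step brings in 1-methyl-1H-indazol-6-yl, so the expectation is only loosely bounded. A further move to a lower number is expected, a 7.1-fold lower number from compound 2 to compound 3 (0.85 log units; beyond the scatter), larger than that modest step but uncertain. The estimate for compound 3 is 250 nM, with an expected range of 25 nM to 1800 nM.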

Compound 3, half-maximal inhibitory concentration: 1000 nM
Compound 3: the middle estimate sits 4.0-fold (0.60 log units) below what was measured; the measured number falls inside the stated range.
By their numbers in this assay, from the lowest: compounds 3 and 2 (each within the scatter of the next); then compound 1.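

In this assay, swapping 4-(trifluoromethyl)phenyl for 1-methyl-1H-indazol-6-yl on this aromatic carbon gives a 1.8-fold lower number from compound 2 to compound 3 (0.25 log units; within the scatter), so the two groups cannot be told apart. Set against the plain phenyl, the fused group gives a 4.7-fold lower number from compound 1 to compound 3 (0.67 log units; beyond the scatter), showing that this position accepts a second, quite different group, one with two hydrogen-bond acceptors, without loss relative to phenyl. Nothing available explains this result. From the compounds shown here alone, whether the methyl on the indazole contributes remains open. So does how an amine or a carboxylic acid would fare at this position.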